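This account rests on a few compounds, and the source may have more. Where it says the series, first, only, none or still open, it means among the compounds named here.

Of the compounds shown here, two have been measured so far in an assay on CHO-K1 cells for displacement of a labelled ligand from adenosine receptor A1 (Homo sapiens), read by scintillation counting, with a stated time of 60 min; a lower number here means a stronger inhibitor, a higher number a weaker inhibitor. Compound 1 `Nc1nc(N/N=C/c2ccc(OCc3ccc(F)cc3)cc2)nc2c1ncn2[C@@H]1O[C@H](CO)[C@@H](O)[C@H]1O` gives 70 nM. Compound 2 `CSCC/C=N/Nc1nc(N)c2ncn([C@@H]3O[C@H](CO)[C@@H](O)[C@H]3O)c2n1` gives > 10000 nM, and this is a limit of the assay rather than a number. Compound 2 therefore stands at the limit of > 10000 nM in this assay, at which 1 of the 2 values shown sits, and can only be said to lie at the weak end of what the assay reports. Compound 3 `Nc1nc(N/N=C/c2ccc(Cl)c(C(F)(F)F)c2)nc2c1ncn2[C@@H]1O[C@H](CO)[C@@H](O)[C@H]1O` has not yet been measured. It differs from compound 2 in one place: 4-chloro-3-(trifluoromethyl)phenyl in place of 2-(methylsulfanyl)ethyl on a carbon with a double bond to nitrogen. Within the data shown here, no step between measured compounds matches this change directly, but an aromatic ring in that place is already seen to be compatible with measurable binding, because compound 1 gives 70 nM. The step that this change implies is expected to be large and toward stronger inhibition, an at least 33-fold lower number from compound 2 to compound 3 (1.52 log units; beyond the scatter). Compound 3 is estimated at 300 nM, with a range from 50 nM to 3000 nM.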

Compound 3, inhibition constant: > 10000 nM
Compound 3: a limit, no number; the forecaster's own chance of this, stated with the estimate: 10%; at least 33-fold (1.52 log units) between middle value and limit.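

No step can be read from compound 2 to compound 3, since each gives only a limit and not a number: the limit of > 10000 nM in this assay, at which 2 of the 3 values shown sit.

The compounds shown leave open which group, 2-(methylsulfanyl)ethyl or 4-chloro-3-(trifluoromethyl)phenyl, gives the stronger inhibitor, and by how much.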